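Shrinking the Amide Substituent of Compound 2

The source may report more compounds than this note shows. Statements on the series, on what has been measured and on what is new or still open speak of the compounds shown alone.

Compound 1 `O=C(COc1ccc2cc(C(O)(C(F)(F)F)C(F)(F)F)c(O)cc2c1)Nc1ccc(-c2ccccc2)cc1` gives 3400 nM in an assay on isolated protein for inhibition of receptor-type tyrosine-protein phosphatase C (Homo sapiens), read by spectrophotometry; on this read-out lower numbers stand for stronger inhibition and higher numbers for weaker inhibition. Compound 2 `CC(C)c1ccc(NC(=O)COc2ccc3cc(C(O)(C(F)(F)F)C(F)(F)F)c(O)cc3c2)cc1` gives 7800 nM in this assay, the higher of the two numbers available, and the step of a 2.3-fold higher number from compound 1 to compound 2 (0.36 log units; beyond the scatter) lies beyond the scatter. Compound 3 `Oc1c(C(O)(C(F)(F)F)C(F)(F)F)ccc2ccccc12`, which has no amide arm at all, reaches only the assay limit > 500000 nM in this assay. Compound 4 `O=C(COc1ccc2cc(C(O)(C(F)(F)F)C(F)(F)F)c(O)cc2c1)NC1CC1` differs from compound 2 by cyclopropyl in place of 4-isopropylphenyl on an amide-type nitrogen. Within the data shown here, the one measured step that bears on this position, from phenyl to isopropyl, was modest in size and pointed toward a higher number; the present change removes the whole aromatic ring from the amide nitrogen, a larger alteration than anything measured, while compound 4 still keeps the amide arm that compound 3 lacks. The account therefore expects a further rise in the number, of a size in this assay estimated as a 2.3-fold higher number from compound 2 to compound 4 (0.36 log units; beyond the scatter). Compound 4 is expected to give about 18000 nM in this assay, with a likely range from 5000 nM to 70000 nM.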

Compound 4, half-maximal inhibitory concentration: > 20000 nM
Compound 4 gave a limit, no number (the forecaster's own chance of this, stated with the estimate: 15%); middle value at least 1.1-fold (0.04 log units) from the limit.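

In this assay compound 4 gives only a limit of the assay, > 20000 nM, and no number. With cyclopropyl on the amide-type nitrogen the record reads an at least 2.5-fold higher number from compound 2 to compound 4 (0.40 log units; beyond the scatter) and an at least 5.8-fold higher number from compound 1 to compound 4 (0.76 log units; beyond the scatter), so at this position the change costs more than the earlier swap from phenyl to isopropyl on the aromatic ring did. Keeping the amide arm with only cyclopropyl on it therefore does not preserve the level seen with 4-isopropylphenyl or 4-phenylphenyl, and the full size of both steps stays unknown.

The compounds shown do not separate the loss of the aromatic ring from the loss of heavy atoms. As far as these compounds go, it remains open whether an unsubstituted phenyl or a longer open carbon chain such as hexyl on this nitrogen would restore the number seen with compound 2.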